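This account rests on a few compounds, and the source may have more. Where it says the series, first, only, none or still open, it means among the compounds named here.

Of the compounds shown here, two sharing one core have been measured in a functional assay on HepG2 cells (Homo sapiens) for antiproliferative activity, read by MTT assay, with a stated time of 3 days; on this read-out higher numbers stand for weaker inhibition and lower numbers for stronger inhibition: compound 1, `CCCCCCCCC#Cc1cn(C/C=C/CN2C(=O)c3ccccc3C2=O)c(=O)[nH]c1=O`, and compound 2, `CCCCc1ccc(C#Cc2cn(C/C=C/CN3C(=O)c4ccccc4C3=O)c(=O)[nH]c2=O)cc1`. In this assay compound 1 gives 43000 nM, while compound 2 gives 9100 nM. Going by the values given here, the single step between them, a 4.7-fold lower number from compound 1 to compound 2 (0.67 log units; beyond the scatter), comes from 4-butylphenyl in place of octyl on a triple-bonded carbon. Of the two numbers available, compound 2 stands at the lowest. Compound 3, `CCCCC#Cc1cn(C/C=C/CN2C(=O)c3ccccc3C2=O)c(=O)[nH]c1=O`, differs from compound 2 by butyl in place of 4-butylphenyl on a triple-bonded carbon. Among the compounds with values here, the only measured step that bears on this change is the one from compound 1 to compound 2, where 4-butylphenyl gave the lower number than octyl; compound 3 returns to a plain chain, butyl, so a higher number in this assay is expected, of a size comparable to that step. Compound 3 is therefore expected to give 30000 nM, in the range 10000 nM to 90000 nM. That expectation corresponds to a step of a 3.3-fold higher number from compound 2 to compound 3 (0.52 log units; beyond the scatter).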

Compound 3, half-maximal inhibitory concentration: 7900 nM
The estimate for compound 3 lay 3.8-fold (0.58 log units) above the measured number, outside the stated range (below it).
By their numbers in this assay, from the lowest: compounds 3 and 2 (each within the scatter of the next); then compound 1.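

In this assay, the six-membered aromatic ring of 4-butylphenyl proves unnecessary for the lower number: with butyl in its place on the triple-bonded carbon, there is a 1.2-fold lower number from compound 2 to compound 3 (0.06 log units; within the scatter). The other new step, a 5.4-fold lower number from compound 1 to compound 3 (0.74 log units; beyond the scatter), shows that a plain chain can also give a number well under that of octyl, so the earlier difference between octyl and 4-butylphenyl did not depend on the ring, and among these three compounds octyl alone stands apart. No measurement at hand explains this result. The compounds shown leave open how the number changes for chains of intermediate length between butyl and octyl, or for a chain shorter than butyl, such as propyl. They also leave open how a plain phenyl, or a chain carrying an amine, would read on the triple-bonded carbon.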